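Swapping the benzyl substituent in a triazole acetamide series

A few compounds are considered here, and "the series" means these few. Any claim that something is new, unique, unknown or untested is made for them only; others in the source may bear on it.

Compound 1, `COc1cccc(NC(=O)CSc2nnc(-c3cc(OC)c(OC)c(OC)c3)n2N)c1`: in a functional assay on PC-3 cells (Homo sapiens) for antiproliferative activity, read by MTT assay, with a stated time of 48 h (a lower number here means a stronger inhibitor, a higher number a weaker inhibitor), it reached only the limit > 100000 nM.
Compound 2, `COc1cc(-c2nnc(SCC(=O)NCc3ccc(Cl)cc3)n2N)cc(OC)c1OC`: in this assay it likewise reached only the limit > 100000 nM.

Compound 2 stands at the limit of this assay, and its value is not a number but a limit. Among the compounds with values here, the same holds for compound 1, and the single step that connects them, a step that the two limits leave unreadable from compound 1 to compound 2, is therefore unreadable in size and direction. Within the data shown here, the only evidence on offer is the limit of > 100000 nM in this assay, at which 2 of the 2 values shown sit, which says that both values shown sit at that limit.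

Compound 3, `COc1ccc(CNC(=O)CSc2nnc(-c3cc(OC)c(OC)c(OC)c3)n2N)cc1OC`, differs from compound 2 by a single change, (3,4-dimethoxyphenyl in place of 4-chlorophenyl on a saturated chain carbon bound to an amide-type nitrogen). Among the measured compounds shown here, no measured step bears on this change, since the one step known could not be read. With compound 2 at the limit and no readable step to lean on, the expectation for compound 3 is no step beyond the scatter, and most likely another limit. The estimated step from compound 2 to compound 3 is a number no higher from compound 2 to compound 3 (the limit leaves the size open). Compound 3 is therefore expected to give about 100000 nM in this assay, within a range from 30000 nM to 300000 nM.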

Compound 3, half-maximal inhibitory concentration: > 100000 nM
Compound 3: no number, only a limit; the forecaster's own chance of this, stated with the estimate: 80%; the middle value lies on the limit itself.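

In this assay, compound 3 reached only a limit, > 100000 nM. The steps linking compound 1, compound 2 and compound 3 therefore cannot be read in size or direction. The compounds shown leave open how 3-methoxyphenyl, 4-chlorobenzyl and 3,4-dimethoxybenzyl on the amide-type nitrogen rank against one another, the only evidence being this: the limit of > 100000 nM in this assay, at which 3 of the 3 values shown sit.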